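Sulfonamide series: tolerated concentration, moving from compound 3 to compound 4

A few compounds are considered here, and "the series" means these few. Any claim that something is new, unique, unknown or untested is made for them only; others in the source may bear on it.

Compound 1 `O=S(=O)(Nc1ccc(-c2nc3ccccc3o2)cc1)c1cccc(Cl)c1` in an ADME assay on HEK293 cells (Homo sapiens) for cytotoxicity, read by resazurin assay, with a stated time of 48 h (a higher number here means that more compound is tolerated, a lower number that less compound is tolerated), gives > 100000 nM, a limit of the assay and not a number.
Compound 2 `O=S(=O)(Nc1ccc2oc(-c3ccccc3)nc2c1)c1ccccc1C(F)(F)F` gives 80000 nM in this assay.
Compound 3 `O=S(=O)(Nc1ccc2oc(-c3ccccc3)nc2c1)c1ccccc1Cl` gives 73000 nM in this assay.

Compound 3 has the lowest of the two numbers shown; its nearest neighbour is compound 2, and the step of a 1.1-fold lower number from compound 2 to compound 3 (0.04 log units; within the scatter) lies within the scatter. The third value is a limit, as the limit of > 100000 nM in this assay, at which 1 of the 3 values shown sits, records.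

Compound 4 `Cc1ccc(S(=O)(=O)Nc2ccc3oc(-c4ccccc4)nc3c2)cc1` is not yet measured. Against compound 3 the difference is 4-methylphenyl in place of 2-chlorophenyl on a sulfonyl sulfur.

Within the data shown here, only one measured step bears on a change to the ring on the sulfonyl sulfur: the step of a 1.1-fold lower number from compound 2 to compound 3 (0.04 log units; within the scatter), a swap of one substituent on that ring, which produced no movement beyond the scatter. The change to compound 4 exchanges the whole ring for 4-methylphenyl, a larger change than that one, but nothing in the series shows a ring exchange at this place altering the read-out. Compound 1, which carries a different core, sits at a limit and gives no number to compare.

The expectation for compound 4 in this assay is therefore a step of a 1.1-fold higher number from compound 3 to compound 4 (0.04 log units; within the scatter), within the scatter. Compound 4 is estimated at 80000 nM, between 35000 nM and 160000 nM.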

Compound 4, half-maximal cytotoxic concentration: 75000 nM
For compound 4 the middle estimate is 1.1-fold (0.03 log units) above the measured one, and the stated range covers the measured number.
By their numbers in this assay, from the lowest: compounds 3, 4 and 2 (each within the scatter of the next). At a limit, above all of these: compound 1.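

Among these compounds, until now the only measured change on the ring at the sulfonyl sulfur was the exchange of one substituent, a 1.1-fold lower number from compound 2 to compound 3 (0.04 log units; within the scatter). Compound 4 goes further, exchanging 2-chlorophenyl for 4-methylphenyl, which replaces chlorine with a carbon substituent and carries a different substitution pattern on the ring, and in this assay the result is a 1.0-fold higher number from compound 3 to compound 4 (0.01 log units; within the scatter). Both exchanges at this place therefore stay within the scatter, so the tolerated concentration has now held across compounds 2, 3 and 4 through a change of ring as well as a change of substituent, a statement limited to these compounds.

From the compounds shown here alone, every group on the sulfonyl sulfur in these compounds is a substituted phenyl ring bearing chloro, trifluoromethyl or methyl, so it remains open whether an amine or a carboxylic acid on that ring, or a longer alkyl chain in place of the ring, would move the number beyond the scatter. Compound 1 differs from the others in more than one place and does not enter these comparisons, and its value is a limit of the assay and not a number: the limit of > 100000 nM in this assay, at which 1 of the 4 values shown sits.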